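Adding a tert-butyl to an inactive amine

A few compounds are considered here, and "the series" means these few. Any claim that something is new, unique, unknown or untested is made for them only; others in the source may bear on it.

Compound 1 `CCCCCNc1oc2c(C)ncc(CO)c2c1Nc1cccc(F)c1` carries a pentylamino group and a fluorophenyl group on its core; in a functional assay on HEK293 cells for agonist activity at Toll-like receptor 8 (Homo sapiens), read by reporter gene assay (on this read-out higher numbers stand for an effect only at larger amounts of compound and lower numbers for an effect already at smaller amounts), compound 1 gives 370 nM. Compound 2 `Cc1ncc(CO)c2c(Nc3ccccn3)c(N)oc12` shares the core with compound 1 but bears a free amino group and a pyridine ring in place of the fluorophenyl; in this assay compound 2 gives "not active" (no number reported), with no number given, so compound 2 stands outside the measured range and no figure can be placed beside it. Compound 3 `Cc1ncc(CO)c2c(Nc3ccccn3)c(NC(C)(C)C)oc12` differs from compound 2 in one place: tert-butyl in place of hydrogen on a nitrogen on an aromatic ring. With compound 1 showing a measurable effect when an alkyl chain sits on that nitrogen, the step from compound 2 to compound 3 is expected to move this assay toward lower numbers, though how far is uncertain. Compound 3 is estimated at 1500 nM, with a likely range from 250 nM to 10000 nM.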

Compound 3, half-maximal effective concentration: "not active" (no number reported)
Compound 3: no number reported, so the estimate cannot be set against anything.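

In this assay compound 2 and compound 3 both stand without a number, so no step can be read between them. Nothing measured here offers an explanation. The compounds shown leave open whether any group on that nitrogen gives a measurable effect alongside the pyridine ring.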